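Longer chain and alkyl groups: compound 3 to compound 4

This account rests on a few compounds, and the source may have more. Where it says the series, first, only, none or still open, it means among the compounds named here.

Measured in a functional assay on LNCaP cells (Homo sapiens) for antiproliferative activity, read by WST assay, with a stated time of 3 days (a lower number here means a stronger inhibitor, a higher number a weaker inhibitor), so far:
Compound 1 `CCCN(CCC)CCCOc1c(-c2cc(OC)c(OC)c(OC)c2)oc2ccccc2c1=O` gives 17900 nM
Compound 2 `CCCN(CCC)CCCCOc1c(-c2cc(OC)c(OC)c(OC)c2)oc2ccccc2c1=O` gives 16800 nM
Compound 3 `CCCCN(CCCC)CCCOc1c(-c2cc(OC)c(OC)c(OC)c2)oc2ccccc2c1=O` gives 9000 nM

Compound 3 stands within the scatter of both others, as a 2.0-fold lower number from compound 1 to compound 3 (0.30 log units; within the scatter) and a 1.9-fold lower number from compound 2 to compound 3 (0.27 log units; within the scatter) show. Compound 4 `CCCCCN(CCCCC)CCCCOc1c(-c2cc(OC)c(OC)c(OC)c2)oc2ccccc2c1=O` differs from it by (dipentylamino)methyl in place of dibutylamino on a saturated chain carbon, three bonds along the chain from an oxygen on an aromatic ring and carries (dipentylamino)methyl in place of dibutylamino on a saturated chain carbon, three bonds along the chain from an oxygen on an aromatic ring. For the measured compounds named here, two steps bear on this: a 1.1-fold lower number from compound 1 to compound 2 (0.03 log units; within the scatter) for (dipropylamino)methyl and a 2.0-fold lower number from compound 1 to compound 3 (0.30 log units; within the scatter) for dibutylamino, both within the scatter. In this assay a small move toward a lower number is therefore expected, namely a 1.6-fold lower number from compound 3 to compound 4 (0.21 log units; within the scatter) and not clearly beyond the scatter. Compound 4 is estimated at 5500 nM within a range of 2000 nM to 14000 nM for this measurement.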

Compound 4, half-maximal inhibitory concentration: 9700 nM
Compound 4: middle estimate off by 1.8-fold (0.25 log units), on the low side; the range from low to high includes it.
By their numbers in this assay, from the lowest: compounds 3, 4, 2 and 1 (each within the scatter of the next).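

In this assay the larger group, (dipentylamino)methyl with 12 heavy atoms in place of the 9 of dibutylamino, gives a 1.1-fold higher number from compound 3 to compound 4 (0.03 log units; within the scatter) and so stays within the scatter. The other two new steps, a 1.7-fold lower number from compound 2 to compound 4 (0.24 log units; within the scatter) and a 1.8-fold lower number from compound 1 to compound 4 (0.27 log units; within the scatter), also stay within it, so growing these alkyl groups on the amine has shown no clear effect at this position. No evidence at hand accounts for this flat result. Going by these compounds, whether a ring amine such as piperidine or a longer chain such as dihexylamino would move the number beyond the scatter remains open.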